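Compound 2 and the swap to a smaller amine

The compounds below may be only part of what the source reports. "The series", "measured", "known", "first", "only" and "open" are said of these compounds alone.

compound 1 `CN(C)Cc1ccc2nc(NC(=O)N/N=C/c3cn(Cc4ccc(C(C)(C)C)cc4)c4ccccc34)sc2c1` gives 810 nM
compound 2 `CC1CCN(Cc2ccc3nc(NC(=O)N/N=C/c4c[nH]c5ccccc45)sc3c2)CC1` gives 4130 nM

In a functional assay on NCI-H460 cells (Homo sapiens) for cytotoxicity, read by MTT assay, with a stated time of 72 h (a lower number here means a stronger inhibitor, a higher number a weaker inhibitor), compound 2 has the higher number of the two measured compounds (4130 nM), so it is the weaker inhibitor, and its gap to compound 1 (810 nM) lies beyond the scatter of repeat measurements.

Compound 3 (`CN(C)Cc1ccc2nc(NC(=O)N/N=C/c3c[nH]c4ccccc34)sc2c1`) has not yet been measured. It matches compound 2 except for one change: dimethylamino in place of 4-methylpiperidin-1-yl on a saturated chain carbon bound to an aromatic carbon.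

For the measured compounds named here, no measured pair shows this change on its own, so any forecast is loose. Compound 3 differs elsewhere from compound 1 (810 nM), which also carries dimethylamino, so that number is no direct guide. The expected change in this assay is therefore none beyond the scatter, an estimated step (a 1.0-fold lower number from compound 2 to compound 3 (0.01 log units; within the scatter)) in either direction. For compound 3 the estimated value is 4000 nM (expected range 1300 nM to 12000 nM).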

Compound 3, half-maximal inhibitory concentration: 2550 nM
The estimate for compound 3 lay 1.6-fold (0.20 log units) above the measured number, within the range that was stated.
By their numbers in this assay, from the lowest: compound 1; then compounds 3 and 2 (each within the scatter of the next).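

In this assay, dimethylamino in place of 4-methylpiperidin-1-yl on a saturated chain carbon bound to an aromatic carbon gives a 1.6-fold lower number from compound 2 to compound 3 (0.21 log units; within the scatter) and so makes no difference that this assay can separate, even though the ring is gone and the group is much smaller. For the compounds shown here, compound 3 also isolates the other difference from compound 1: hydrogen in place of 4-(tert-butyl)benzyl on an aromatic nitrogen gives a 3.1-fold higher number from compound 1 to compound 3 (0.50 log units; beyond the scatter) and is the only one of these two changes that lies beyond the scatter. No supporting measurement shows why either step has the size it does.

On these data alone, it remains open whether another amine at the saturated chain carbon, such as morpholin-4-yl or a primary amine, would also stay within the scatter of compound 3, and whether the amine swap would behave the same way with 4-(tert-butyl)benzyl on the aromatic nitrogen. A simpler group on that nitrogen, such as methyl or unsubstituted benzyl, would show how much of the larger group is needed for the step seen from compound 1.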